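Pyrazolyl for Triazolyl in a Short-Lived Aroyl Sulfonylhydrazide Series

A few compounds are considered here, and "the series" means these few. Any claim that something is new, unique, unknown or untested is made for them only; others in the source may bear on it.

The account follows three measured aroyl sulfonylhydrazides and one that is still to be tested in an ADME assay on microsomes from liver (Mus musculus) for metabolic stability, read by HPLC, using NADPH, with a stated time of 60 min, tested at 1 uM, in the presence of a further agent that is not named here; on this read-out higher numbers stand for a longer-lived compound and lower numbers for a shorter-lived compound. Compound 1 `C=CCOc1cc(F)cc(C(=O)NNS(=O)(=O)c2ccccc2F)c1` gives 0.0333 h in this assay. Compound 2 `Cc1cc(-n2nccn2)cc(C(=O)NNS(=O)(=O)c2ccccc2)c1F` gives 0.0333 h in this assay, which is level with compound 1 at the digits reported and within the scatter of that value. Compound 3 `Cc1cc(OC(C)C)cc(C(=O)NNS(=O)(=O)c2ccccc2F)c1` sits at the limit of this assay, reported as < 0.0334 h and not as a number. Thus (the limit of < 0.0334 h in this assay, at which 1 of the 3 values shown sits), and the two numbers that are reported both lie right beside it; no compound among the three is distinguished from the others beyond the scatter.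

The step under consideration leads from compound 2 to compound 4 `Cc1cc(-n2cccn2)cc(C(=O)NNS(=O)(=O)c2ccccc2)c1F`, not yet measured in this assay. The structural change is 1H-pyrazol-1-yl in place of 2H-1,2,3-triazol-2-yl on an aromatic carbon. Going by the values given here, no step between measured compounds is available that would show what such a change does here, so the expectation rests only on where compound 2 stands. The expected step is a 1.1-fold higher number from compound 2 to compound 4 (0.02 log units; within the scatter), that is, none beyond the scatter. Compound 4 is accordingly expected to give 0.035 h in this assay, with a likely range from 0.02 h to 0.08 h.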

Compound 4, half-life in the Mus musculus assay: 0.05 h
Beside the measured number, compound 4's estimate is 1.4-fold (0.15 log units) below it, within the range that was stated.
By their numbers in the Mus musculus assay, from the lowest: compounds 1, 2 and 4 (each within the scatter of the next).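

Going by these compounds alone, in the Mus musculus assay, 1H-pyrazol-1-yl in place of 2H-1,2,3-triazol-2-yl gives a 1.5-fold higher number from compound 2 to compound 4 (0.18 log units; within the scatter), the first direct reading of this change at this position, on the aromatic carbon para to a fluoro group, and it does not separate the two compounds on this read-out. In a physicochemical assay for solubility, read by nephelometry, measured as kinetic solubility, at pH 2 (on this read-out higher numbers stand for higher solubility and lower numbers for lower solubility), compound 2 gives 25 ug/mL and compound 4 gives 6.3 ug/mL. The same change therefore leaves half-life within the scatter but lowers solubility beyond it, so the physicochemical assay and not the Mus musculus assay distinguishes the pair: the measured solubility of compound 2, 25 ug/mL, and of compound 4, 6.3 ug/mL, a 4.0-fold lower number (0.60 log units; beyond the scatter)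

As far as these compounds go, whether an amine or a carboxylic acid on this aromatic carbon, in place of the five-membered ring, would lift the half-life clear of the scatter in the Mus musculus assay remains open. Within the data shown here, with only this one pair to go on, it is also open whether the same change would have a similar effect on either read-out on another core, such as that of compound 1.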